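This account rests on a few compounds, and the source may have more. Where it says the series, first, only, none or still open, it means among the compounds named here.

Compound 1 `Cc1ccc2[nH]c(=O)c(CN(CCCO)Cc3ccc(C(C)(C)C)cc3)cc2c1` carries a 3-hydroxypropyl group on the amine nitrogen of the shared core. In a toxicity assay on MDCK cells (Canis lupus familiaris) for cytotoxicity, read by crystal violet staining, with a stated time of 48 h (on this read-out higher numbers stand for lower toxicity in this test and lower numbers for higher toxicity in this test), compound 1 gives only a limit, > 10000 nM. Compound 2 `COc1ccc(C(C)N(Cc2ccc(C(C)(C)C)cc2)Cc2cc3cc(C)ccc3[nH]c2=O)cc1` carries 1-(4-methoxyphenyl)ethyl in place of 3-hydroxypropyl on that nitrogen. In this assay compound 2 also gives only a limit, > 5000 nM. The step that the two limits leave unreadable from compound 1 to compound 2 therefore cannot be read in size or direction. Compound 1 sits at the limit of > 10000 nM in this assay, at which 1 of the 2 values shown sits. Compound 2 sits at the limit of > 5000 nM in this assay, at which 1 of the 2 values shown sits. On the numbers shown, compound 2 thus stands at a limit and nothing further is known of its place in the series.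

Compound 3 `COc1ccc(C(C)N(Cc2ccc(C(C)(C)C)cc2)Cc2cc3cc(C)ccc3[nH]c2=O)cc1Cl` differs from compound 2 by chloro in place of hydrogen on an aromatic carbon. Among the compounds with values here, no measured step bears on this change: the only step available, from compound 1 to compound 2, concerns a different position and is itself unreadable. Nothing in the data points to a change beyond the scatter in this assay, and a value at or near the limit is expected again. For compound 3 the estimate in this assay is 8000 nM, within 3000 nM to 30000 nM, which means an expected step that the limit leaves unreadable from compound 2 to compound 3.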

Compound 3, half-maximal cytotoxic concentration: > 10000 nM
Compound 3 ended at the assay's limit (the forecaster's own chance of this, stated with the estimate: 85%); middle value at least 1.2-fold (0.09 log units) from the limit.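

In this assay compound 3 gives only a limit, > 10000 nM. Within the data shown here, with compound 1 and compound 2 also at limits, no step among the three can be read in size or direction. The compounds shown leave open where the half-maximal cytotoxic concentration of each lies, and whether either change alters it at all.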